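From nitrile to trifluoromethyl: a step without a baseline

This account rests on a few compounds, and the source may have more. Where it says the series, first, only, none or still open, it means among the compounds named here.

compound 1 `O=C(Nc1cc(C(F)(F)F)cc(C(F)(F)F)c1)c1cc(Cl)c(F)cc1O` gives 730 nM
compound 2 `N#Cc1cccc(NC(=O)c2cc(F)ccc2O)c1` gives "not determined" (no result reported)
compound 3 `N#Cc1ccc(NC(=O)c2ccc3cccnc3c2O)c(F)c1` gives 420 nM

Within the data shown here, in a functional assay on Jurkat cells (Homo sapiens) for cytotoxicity, read by luminescence and CellTiter-Glo, with a stated time of 3 days (a lower number here means a stronger inhibitor, a higher number a weaker inhibitor), compound 2 has no number to stand on, as its entry reads "not determined" (no result reported) and no measured step links it to the other compounds. The structural change is trifluoromethyl in place of cyano on an aromatic carbon and it leads to compound 4 `O=C(Nc1cccc(C(F)(F)F)c1)c1cc(F)ccc1O` as the next structure. A moderate step towards stronger inhibition is expected, although it cannot be sized from compound 2. Among the measured compounds shown here, the only guide is compound 1 (730 nM) which also carries trifluoromethyl, on a different core. Compound 4 is expected to give 1500 nM with an estimated range from 500 nM to 5000 nM overall.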

Compound 4, half-maximal inhibitory concentration: 840 nM
Compound 4: the middle estimate sits 1.8-fold (0.25 log units) above what was measured; the measured number falls inside the stated range.
By their numbers in this assay, from the lowest: compounds 3, 1 and 4 (each within the scatter of the next).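

Compound 4 yields no readable step: compound 2 offers no value for comparison, and compounds 1 and 3 differ from it in more than one place. From the compounds shown here alone, the effect of trifluoromethyl in place of cyano stays open. No available evidence bears on this result.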